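The source may hold more compounds than are shown below. What is called first, only, known or untested is meant among the compounds shown, and "the series" means these compounds.

Compound 1 `CC(C)(C)c1ccc(NC(=O)c2ccc(-c3ncccc3NC3CCCC3)cc2)cc1` gives 190 nM in a functional assay for antagonist activity at transient receptor potential cation channel subfamily V member 1 (Homo sapiens), read by FLIPR; on this read-out lower numbers stand for stronger inhibition and higher numbers for weaker inhibition. Compound 2 `CC(C)(C)c1ccc(NC(=O)c2ccc(-c3ncccc3C(=N)N)cc2)cc1` reaches only a limit of this assay, > 4000 nM. For the measured compounds named here, the step of an at least 21-fold higher number from compound 1 to compound 2 (1.32 log units; beyond the scatter) is the only measured change, and it sits at the limit of > 4000 nM in this assay, at which 1 of the 2 values shown sits, so its full size is unknown. Compound 3 `CC(C)(C)c1ccc(NC(=O)c2ccc(-c3ncccc3-c3nn[nH]n3)cc2)cc1` carries the 2H-tetrazol-5-yl group in place of the open chain of compound 2 (a group of 5 heavy atoms (1 carbon, 4 nitrogen; one five-membered aromatic ring with 4 hetero atoms) in place of a group of 3 heavy atoms (1 carbon, 2 nitrogen; no ring), on an aromatic carbon), ortho to a large group. Going by the values given here, no measured step covers this exchange, so no direction beyond the scatter can be expected; compound 3 is estimated at 5000 nM, between 1000 nM and 25000 nM, an expected step that the limit leaves unreadable from compound 2 to compound 3.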

Compound 3, half-maximal inhibitory concentration: > 4000 nM
Compound 3: a limit, no number; the forecaster's own chance of this, stated with the estimate: 55%; the middle value lies beyond the limit too.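

Exchanging cyclopentylamino for 2H-tetrazol-5-yl on this aromatic carbon gives an at least 21-fold higher number from compound 1 to compound 3 (1.32 log units; beyond the scatter). A ring in the entering group therefore does not by itself return a readable number: of the compounds shown, only compound 1, with cyclopentylamino, has one. The step from compound 2 to compound 3 cannot be read, as both values are limits, not numbers: the limit of > 4000 nM in this assay, at which 2 of the 3 values shown sit.

As far as these compounds go, how far compound 2 and compound 3 lie past that limit stays open. So does whether a cyclopentyloxy group or a smaller amine such as methylamino at this place would give a readable number.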